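From Secondary to Tertiary Amide at the Highest Value

A few compounds are considered here, and "the series" means these few. Any claim that something is new, unique, unknown or untested is made for them only; others in the source may bear on it.

Of the compounds shown here, three that share one core have been measured in a functional assay on the whole organism (strain Wistar) for inhibition, with Rattus norvegicus as the target, read by paw edema, with stated times of 60 min and 4 h, at a dose of 100 mg/kg by the oral route; on this read-out higher numbers stand for more inhibition at the one dose given (going by the name of the read-out) and lower numbers for less inhibition. Compound 1 `CCCCNC(=O)CC1CCc2cc(OC)c(OC)cc21` gives 25%, compound 2 `COc1cc2c(cc1OC)C(CC(=O)NC(C)(C)C)CC2` gives 32.8%, and compound 3 `COc1cc2c(cc1OC)C(CC(=O)NC1CCCCC1)CC2` gives 50%. Compound 3 stands highest of the three: the step of a number 17.2 percentage points higher from compound 2 to compound 3 (beyond the scatter) lies beyond the scatter, as does a number 25 percentage points higher from compound 1 to compound 3 (beyond the scatter), while a number 7.8 percentage points higher from compound 1 to compound 2 (within the scatter) stays within it.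

Compound 4 `COc1cc2c(cc1OC)C(CC(=O)N1CCCCC1)CC2` is not yet measured. It differs from compound 3 in one place: piperidin-1-yl in place of cyclohexylamino on a carbonyl carbon. Every step measured so far exchanges one group for another on the amide-type nitrogen while the amide hydrogen remains; the steps of a number 25 percentage points higher from compound 1 to compound 3 (beyond the scatter) and a number 17.2 percentage points higher from compound 2 to compound 3 (beyond the scatter) show that the choice of group on that nitrogen moves the read-out in this assay by modest amounts. For the measured compounds named here, no measured step removes the hydrogen-bond donor or joins the nitrogen into a ring, so the direction of the present change cannot be read from any measured pair. The step expected in this assay is a number 12 percentage points lower from compound 3 to compound 4 (beyond the scatter), a modest fall carried with wide uncertainty. Compound 4 is estimated at 38% in this assay, within an expected range from 20% to 55%.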

Compound 4, a percentage reported as inhibition, in the whole organism at one dose (the size of the read-out at that dose, not a potency): 32%
Compound 4: the middle estimate sits 6 percentage points above what was measured; the measured number falls inside the stated range.
By their numbers in this assay, from the lowest: compounds 1, 4 and 2 (each within the scatter of the next); then compound 3.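

In this assay, for the compounds shown here, the change from cyclohexylamino to piperidin-1-yl on a carbonyl carbon is the first measured step that removes the amide hydrogen, and it gives a number 18 percentage points lower from compound 3 to compound 4 (beyond the scatter). Both groups bring a six-membered non-aromatic ring, so a ring of that size on the amide nitrogen does not by itself go with the highest value among these compounds. Going by these compounds alone, with a number 0.8 percentage points lower from compound 2 to compound 4 (within the scatter) and a number 7 percentage points higher from compound 1 to compound 4 (within the scatter), cyclohexylamino is the only one of the four groups on this carbonyl carbon whose value stands apart from the others.

No other kind of measurement is at hand to explain the drop.

The compounds shown cannot separate the loss of the amide hydrogen from the joining of the nitrogen into a ring, since they include no open-chain group without that hydrogen, such as diethylamino. From the compounds shown here alone, it also remains open how a morpholin-4-yl or pyrrolidin-1-yl group on the same carbonyl carbon would read in this assay, and whether either would stay within the scatter of the piperidin-1-yl amide.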